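A Large Phenoxy Group Gives Way to Nitro

The source may hold more compounds than are shown below. What is called first, only, known or untested is meant among the compounds shown, and "the series" means these compounds.

Compound 1 (`CC(C)[C@H](NC(=O)COc1cccc2ccccc12)C(=O)N[C@@H](CC(=O)O)C(=O)COc1ccc(C(N)=O)cc1`) and compound 2 (`CC(C)[C@H](NC(=O)COc1cccc2ccccc12)C(=O)N[C@@H](CC(=O)O)C(=O)COc1ccc(Oc2ccc(C(F)(F)F)cc2)cc1`) differ in one group on a shared core. In a functional assay on Jurkat cells (Homo sapiens) (on this read-out lower numbers stand for stronger inhibition and higher numbers for weaker inhibition), compound 1 gives > 100000 nM, which is a limit of the assay and not a number. Going by the values given here, compound 2 gives 9300 nM, the only true number so far.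

Compound 3 (`CC(C)[C@H](NC(=O)COc1cccc2ccccc12)C(=O)N[C@@H](CC(=O)O)C(=O)COc1ccc([N+](=O)[O-])cc1`) carries nitro in place of 4-(trifluoromethyl)phenoxy on an aromatic carbon. Among the compounds with values here, one measured step bears on this change, the exchange of carbamoyl for 4-(trifluoromethyl)phenoxy, and it was large: an at least 10-fold lower number from compound 1 to compound 2 (1.03 log units; beyond the scatter). Its size is open-ended, as it starts from the limit of > 100000 nM in this assay, at which 1 of the 2 values shown sits. Compound 3 also loses that group, so a large move toward weaker inhibition in this assay is expected, though nitro is not carbamoyl. The expected change is a 4.3-fold higher number from compound 2 to compound 3 (0.63 log units; beyond the scatter). Compound 3 is estimated at 40000 nM, within an expected range of 12000 nM to 100000 nM.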

Compound 3, half-maximal inhibitory concentration: > 100000 nM
Compound 3: no number, only a limit; the forecaster's own chance of this, stated with the estimate: 35%; at least 2.5-fold (0.39 log units) between middle value and limit.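

Setting nitro in place of 4-(trifluoromethyl)phenoxy on this aromatic carbon gives an at least 10-fold higher number from compound 2 to compound 3 (1.03 log units; beyond the scatter). In this assay compound 3 reads > 100000 nM, which is a limit of the assay and not a number. Now two different groups at this place, carbamoyl in compound 1 and nitro in compound 3, both end at the limit, so the step between those two compounds cannot be read, and only compound 2, with its 4-(trifluoromethyl)phenoxy, keeps a true number: the limit of > 100000 nM in this assay, at which 2 of the 3 values shown sit.

It remains open which part of the 4-(trifluoromethyl)phenoxy group carries the difference, since a plain phenoxy, a phenyl joined without the ether oxygen or a trifluoromethyl alone is not among the compounds shown. From the compounds shown here alone, how far compound 1 and compound 3 lie beyond the limit also stays unknown.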